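Trimming a Benzyl Group on a Purine Nucleoside Core

This account rests on a few compounds, and the source may have more. Where it says the series, first, only, none or still open, it means among the compounds named here.

Measured compounds:
Compound 1 `C=CCn1c(=O)n(C2C=CC(CO)O2)c2nc(N)nc(O)c21` gives 11 uM in a functional assay on YAC-1 cells (Mus musculus) for activation; a higher number here means that more compound is needed for the effect, a lower number that less compound is needed.
Compound 2 `Nc1nc(O)c2c(n1)n(C1OC(CO)[C@@H](O)[C@H]1O)c(=O)n2Cc1ccc(Cl)cc1` gives 180 uM in this assay.

Of the two compounds measured, compound 2 stands at the higher number, and its nearest neighbour, compound 1, sits far enough below it that the gap lies beyond the usual scatter of repeated measurements. Among the compounds with values here, only two compounds have been measured, and they differ in more than one place. Within the data shown here, no single step between measured compounds is available to anchor a trend.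

The next compound, compound 3 `Cn1c(=O)n(C2OC(CO)[C@@H](O)[C@H]2O)c2nc(N)nc(O)c21`, keeps the sugar and the core of compound 2 and changes only one thing: hydrogen in place of 4-chlorophenyl on a saturated chain carbon bound to an aromatic nitrogen. This is a large piece leaving and almost nothing entering.

Without a measured step for a comparable change, the size of the effect in this assay is uncertain. Given that compound 1, the compound with the smaller group at this position, gave 11 uM, a moderate move toward a lower number is expected, with a wide range. The step from compound 2 to compound 3 is estimated at a 3.0-fold lower number from compound 2 to compound 3 (0.48 log units; beyond the scatter). Compound 3 is expected to give roughly 60 uM, most likely between 12 uM and 300 uM.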

Compound 3, concentration for half-maximal effect: 56 uM
Estimate against measurement, compound 3: 1.1-fold (0.03 log units) above; measured number inside the range.
By their numbers in this assay, from the lowest: compound 1; then compound 3; then compound 2.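

In this assay, within the data shown here, the cut from 4-chlorobenzyl to methyl, with the sugar and the core kept, gives a 3.2-fold lower number from compound 2 to compound 3 (0.51 log units; beyond the scatter) and is the first change that can be read in one place alone. The 4-chlorophenyl ring and its 7 heavy atoms are therefore not required for activation of these cells, and less compound is needed once they are gone. No measurement shown here explains why the number falls, so the step stands as an observation only.

What the compounds leave open is whether the ring as a whole or only its chlorine accounts for the step, and whether a plain benzyl, an ethyl or a longer chain would land nearer compound 2 or compound 3. Compound 1 carries an allyl group and also a different sugar, so its lower number cannot be credited to either difference alone.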